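The source may report more compounds than this note shows. Statements on the series, on what has been measured and on what is new or still open speak of the compounds shown alone.

Series notes, para-substituent on the aryl group of the shared core.

Compound 1 `CC(C)(C)c1ccc(-c2cc(N3CCC(CCNS(N)(=O)=O)CC3)ncn2)cc1` gives 18400 nM in a functional assay on M21 cells (Homo sapiens) for antiproliferative activity, read by sulforhodamine B assay, with a stated time of 48 h; a higher number here means a weaker inhibitor of growth, a lower number a stronger inhibitor of growth. Compound 2 `COc1ccc(-c2cc(N3CCC(CCNS(N)(=O)=O)CC3)ncn2)cc1` gives 69800 nM in this assay, and compound 3 `NS(=O)(=O)NCCC1CCN(c2cc(-c3ccc(Cl)cc3)ncn2)CC1` gives 45200 nM. Compound 3 stands second highest of the three numbers; its gap to compound 2 lies within the scatter, while the gap to compound 1 lies beyond it, as a 2.5-fold higher number from compound 1 to compound 3 (0.39 log units; beyond the scatter) shows. The other measured steps are a 3.8-fold higher number from compound 1 to compound 2 (0.58 log units; beyond the scatter) and a 1.5-fold lower number from compound 2 to compound 3 (0.19 log units; within the scatter).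

Compound 4 `NS(=O)(=O)NCCC1CCN(c2cc(-c3ccc(C(F)(F)F)cc3)ncn2)CC1` is not yet measured. It differs from compound 3 by trifluoromethyl in place of chloro on an aromatic carbon. Among the measured compounds shown here, no measured step replaces chloro with trifluoromethyl. For the measured compounds named here, the steps that bear on it are the tert-butyl exchanges, a 2.5-fold higher number from compound 1 to compound 3 (0.39 log units; beyond the scatter) and a 3.8-fold higher number from compound 1 to compound 2 (0.58 log units; beyond the scatter), both modest. Compound 2 and compound 3 differ only within the scatter, so the exchange of one small group for another has so far produced nothing firm. A step of a 1.5-fold lower number from compound 3 to compound 4 (0.18 log units; within the scatter) is expected, small and possibly within the scatter. Compound 4 is therefore estimated at 30000 nM in this assay, with a range from 12000 nM to 80000 nM.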

Compound 4, concentration for 50% growth inhibition: 34800 nM
Beside the measured number, compound 4's estimate is 1.2-fold (0.06 log units) below it; low and high end bracket the measured number.
By their numbers in this assay, from the lowest: compounds 1, 4, 3 and 2 (each within the scatter of the next, the first and the last beyond it).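

At this position, on an aromatic carbon para to a large group, four heavy atoms of trifluoromethyl enter for the one of chloro, yet the exchange gives a 1.3-fold lower number from compound 3 to compound 4 (0.11 log units; within the scatter) in this assay and so yields no firm change. Among the compounds shown here, compound 4 also lies within the scatter of both ends of the set, with a 2.0-fold lower number from compound 2 to compound 4 (0.30 log units; within the scatter) and a 1.9-fold higher number from compound 1 to compound 4 (0.28 log units; within the scatter) as its two steps, so tert-butyl on one side and methoxy and chloro on the other, which the earlier compounds set apart, are now joined by an intermediate-free run of values in which only the end members separate. No measurement at hand accounts for these numbers.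

Open, on these data alone, is whether an amine or a carboxylic acid on this carbon would move the number beyond the scatter of this set. Also open, as far as these compounds go, is whether a change elsewhere on the shared core counts for more than this position does.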